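A few compounds are considered here, and "the series" means these few. Any claim that something is new, unique, unknown or untested is made for them only; others in the source may bear on it.

Measured so far:
Compound 1 `C=Cc1cccc(-c2[nH]c3cc(OC)ccc3c(=O)c2C(=O)OCC)c1`: in an ADME assay on Raji cells (Homo sapiens) for cytotoxicity, read by luminescence, with a stated time of 72 h (a lower number here means that less compound is needed, a higher number that more compound is needed for the effect), compound 1 gives > 21500 nM, which is a limit of the assay.
Compound 2 `CCOC(=O)c1c(-c2cccc(C(F)(F)F)c2)[nH]c2cc(OC)ccc2c1=O`: in this assay compound 2 gives > 21500 nM, which is also a limit of the assay.

Going by the values given here, the single step within the measured pair, a step that the two limits leave unreadable from compound 1 to compound 2, cannot be read as a size. On the numbers shown, compound 2 stands at the limit of > 21500 nM in this assay, at which 2 of the 2 values shown sit, with no number behind it.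

Compound 3 `CCOC(=O)c1c(-c2cccc(O)c2)[nH]c2cc(OC)ccc2c1=O` differs from compound 2 by hydroxy in place of trifluoromethyl on an aromatic carbon. Among the compounds with values here, no measured step informs a change of this kind, and the only step available is unreadable, so no direction or size beyond the scatter can be expected from the data; the working assumption is that compound 3 stays at the same limit in this assay. The step is therefore estimated as a step that the limit leaves unreadable from compound 2 to compound 3. Compound 3 is expected to give about 30000 nM, within a range from 8000 nM to 100000 nM.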

Compound 3, half-maximal effective concentration: > 21500 nM
Compound 3 ended at the assay's limit (the forecaster's own chance of this, stated with the estimate: 80%); the middle value is on the limit's open side.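

No step among compound 1, compound 2 and compound 3 can be read in this assay, since each value is a limit of the assay and not a number: the limit of > 21500 nM in this assay, at which 3 of the 3 values shown sit.

The compounds shown leave open whether exchanging vinyl, trifluoromethyl and hydroxy changes the concentration needed in this assay, and in which direction and by how much.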